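Carbamate Pyrrolidine Amide Exchanged for an Azetidine Urea

A few compounds are considered here, and "the series" means these few. Any claim that something is new, unique, unknown or untested is made for them only; others in the source may bear on it.

Compound 1 `CCN(CC)S(=O)(=O)c1ccc(S(=O)(=O)N2CCC[C@@H](C(=O)N[C@@H]3CCN(C(=O)OC(C)(C)C)C3)C2)cc1`: 400 nM
Compound 2 `CCOC(=O)[C@@H]1CCC[C@@H](S(=O)(=O)c2ccc(S(=O)(=O)N(CC)CC)cc2)C1`: 18500 nM
Compound 3 `CCOC(=O)[C@H]1CCN(S(=O)(=O)c2ccc(S(=O)(=O)N(CC)CC)cc2)C1`: 29300 nM

In a functional assay on BXPC-3 cells (Homo sapiens) for inhibition, read by MTT assay, with a stated time of 7 days (on this read-out higher numbers stand for weaker inhibition and lower numbers for stronger inhibition), compound 1 gives the lowest number of the three measured compounds. Compound 2 stands well above it and compound 3 higher still, both gaps lying beyond the usual scatter of this assay, so compound 1 is the strongest inhibitor among those measured so far.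

Compound 4 `CCN(CC)S(=O)(=O)c1ccc(S(=O)(=O)N2CCC[C@@H](C(=O)NC3CN(C(=O)NC(C)(C)C)C3)C2)cc1` is built from compound 1 by one exchange: 1-((tert-butyl)carbamoyl)azetidin-3-yl in place of 1-(tert-butoxycarbonyl)pyrrolidin-3-yl on an amide-type nitrogen. Among the measured compounds shown here, no measured pair shows this exchange, so its effect is not known from the data; the two groups are close in size, and the amide linkage to the piperidine core of compound 1 is kept. An expectation can therefore rest only on that resemblance, and the step is expected to be small, likely within or just beyond the scatter, with no direction firmly indicated.

The step from compound 1 to compound 4 is estimated at a 1.5-fold higher number from compound 1 to compound 4 (0.18 log units; within the scatter). For compound 4 the estimate in this assay is 600 nM, expected to fall between 200 nM and 2500 nM.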

Compound 4, half-maximal inhibitory concentration: 10100 nM
Estimate against measurement, compound 4: 17-fold (1.23 log units) below; the measured number lies above the stated range.
By their numbers in this assay, from the lowest: compound 1; then compounds 4, 2 and 3 (each within the scatter of the next, the first and the last beyond it).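

Among the compounds shown here, the exchange on the amide-type nitrogen gives a 25-fold higher number from compound 1 to compound 4 (1.40 log units; beyond the scatter) in this assay, a step at this place that the earlier compounds could not provide, and it shows that inhibition responds strongly to what is carried there. The change is not a single one: a four-membered ring replaces a five-membered one, a tert-butyl carbamoyl group replaces a tert-butoxycarbonyl group, a hydrogen-bond donor enters, and a defined stereocentre leaves. Nothing measured here accounts for the drop.

Which of these differences carries the step remains open, and 1-(tert-butoxycarbonyl)azetidin-3-yl or 1-((tert-butyl)carbamoyl)pyrrolidin-3-yl would separate the ring from the linkage. Also open, on these data alone, is how a free secondary amine in that ring, without any tert-butyl cap, would compare with compound 1.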